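Hydroxy for methoxy on a dimethylaminophenyl-bearing pyridine series

A few compounds are considered here, and "the series" means these few. Any claim that something is new, unique, unknown or untested is made for them only; others in the source may bear on it.

Measured so far:
compound 1, `Cc1cc(O)cc(-c2nn(CC#N)cc2-c2ccnc(-c3ccc(Oc4ccccc4)cc3)c2)c1`: 22%
compound 2, `COc1cc(C)cc(-c2nn(CC#N)cc2-c2ccnc(-c3ccc(N(C)C)cc3)c2)c1`: -2%

Of the compounds shown here, two have been measured in a functional assay on SF-268 cells (Homo sapiens) for cytotoxicity, read by sulforhodamine B assay, with a stated time of 48 h, tested at 1 uM; a lower number here means a stronger effect, a higher number a weaker effect of the compound at the concentration tested. Compound 1 gives 22%, while compound 2 gives -2%. Compound 2 thus holds the lowest of the two numbers; its nearest neighbour is compound 1, whose number is higher by a gap beyond the scatter. The two differ in more than one place, so their values show only where each stands, not what any single change does.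

Compound 3, `Cc1cc(O)cc(-c2nn(CC#N)cc2-c2ccnc(-c3ccc(N(C)C)cc3)c2)c1`, has not yet been measured. It differs from compound 2 in one place: hydrogen in place of methyl on an oxygen on an aromatic ring. Among the compounds with values here, no measured pair shows this change on its own, so its effect in this assay cannot be read off directly. The change is small, and a step that stays within the scatter or rises modestly is expected. Compound 3 is therefore estimated at 8%, with a range of -10% to 28%, which means an expected step of a number 10 percentage points higher from compound 2 to compound 3 (within the scatter).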

Compound 3, a percentage reported as activity, at one concentration (the size of the read-out at that concentration, not a potency): 17%
Estimate against measurement, compound 3: 9 percentage points below; the range from low to high includes it.
By their numbers in this assay, from the lowest: compound 2; then compounds 3 and 1 (each within the scatter of the next).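

In this assay, within the data shown here, methoxy to hydroxy on the 3-methoxy-5-methylphenyl group gives a number 19 percentage points higher from compound 2 to compound 3 (beyond the scatter), the first reading of a single change at this place, and it shows that the methyl on this oxygen matters to the effect at the concentration tested. With hydroxy held fixed, dimethylamino in place of phenoxy on an aromatic carbon gives a number 5 percentage points lower from compound 1 to compound 3 (within the scatter), so these two groups cannot be told apart in this read-out. No measurement at hand accounts for the step from methoxy to hydroxy.

The compounds shown leave open whether the same step would appear with phenoxy in place of dimethylamino. They also leave open what a longer chain on this oxygen, such as ethyl, or an amine in place of the hydroxy group would give.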